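The source may report more compounds than this note shows. Statements on the series, on what has been measured and on what is new or still open speak of the compounds shown alone.

In a functional assay on MDA-MB-231 cells (Homo sapiens) for antiproliferative activity, read by CCK-8 assay and cell counting, with a stated time of 72 h (on this read-out higher numbers stand for weaker inhibition and lower numbers for stronger inhibition), compound 3 (`CCc1ccc(C(=O)Nc2ccccc2)cc1`) gives > 100000 nM, which is a limit of the assay and not a number. Compound 1 (`O=C(Nc1ccccc1)c1ccc(CCl)cc1`) gives 800 nM and compound 2 (`O=C(Nc1ccccc1)c1ccc(CO[N+](=O)[O-])cc1`) gives 800 nM; between them, no change at the digits printed from compound 1 to compound 2 (within the scatter). Among the compounds with values here, two measured steps bear on the next change, both large: an at least 120-fold higher number from compound 1 to compound 3 (2.09 log units; beyond the scatter), and an at least 120-fold higher number from compound 2 to compound 3 (2.09 log units; beyond the scatter). Compound 4 (`O=C(Nc1ccccc1)c1ccc(CO)cc1`) differs from compound 3 by hydroxy in place of methyl on a saturated chain carbon bound to an aromatic carbon. Compound 4 holds neither chloro nor nitrooxy, so no return of the size of an at least 120-fold higher number from compound 2 to compound 3 (2.09 log units; beyond the scatter) is expected in this assay, only a modest move to lower numbers or none. The expected step is small: an at least 2.0-fold lower number from compound 3 to compound 4 (0.30 log units; that floor lies within the scatter). Compound 4 is estimated at 50000 nM, with a range of 10000 nM to 150000 nM.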

Compound 4, half-maximal inhibitory concentration: > 100000 nM
Compound 4 was reported as a limit; the forecaster's own chance of this, stated with the estimate: 60%; middle value at least 2.0-fold (0.30 log units) away from the limit.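

In this assay, hydroxy does not stand in for chloro or nitrooxy on a saturated chain carbon bound to an aromatic carbon: the record shows an at least 120-fold higher number from compound 1 to compound 4 (2.09 log units; beyond the scatter) and an at least 120-fold higher number from compound 2 to compound 4 (2.09 log units; beyond the scatter). An oxygen on this carbon is therefore not enough by itself, since compound 2 keeps its activity through nitrooxy while compound 4 does not through hydroxy. Compound 4 gives a limit of the assay, not a number, and its step from compound 3 cannot be read: the limit of > 100000 nM in this assay, at which 2 of the 4 values shown sit.

Going by these compounds, whether bromo or an amine on this carbon would match compound 1 or fall to the limit stays open. Any order between compound 3 and compound 4 also stays open.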